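A few compounds are considered here, and "the series" means these few. Any claim that something is new, unique, unknown or untested is made for them only; others in the source may bear on it.

Going by the values given here, the three compounds measured so far share one core, and in an assay on HEK293 cells for inhibition of neurogenic locus notch homolog protein 1 (Homo sapiens), read by a luciferase reporter and resazurin assay, with a stated time of 16 h (a lower number here means a stronger inhibitor, a higher number a weaker inhibitor), their numbers spread widely. Compound 1 `CC1=C(C(=O)OC2CCCCC2)C(c2cccc(C#N)c2)C2=C(CC(C)(C)CC2=O)N1` gives 43200 nM. Compound 2 `CC1=C(C(=O)OCc2ccc(C(C)(C)C)cc2)C(c2cccc(Br)c2)C2=C(CC(C)(C)CC2=O)N1` gives 4270 nM. Compound 3 `CC1=C(C(=O)OCC2CCN(C(=O)OC(C)(C)C)CC2)C(c2cccc(C#N)c2)C2=C(CC(C)(C)CC2=O)N1` gives 220 nM, the lowest of the three numbers; its gap to compound 2 and the wider gap to compound 1 both lie beyond the usual scatter of this assay. Compound 4 `CC1=C(C(=O)OCC2CCN(C(=O)OC(C)(C)C)CC2)C(c2cccc(C(F)(F)F)c2)C2=C(CC(C)(C)CC2=O)N1` has not yet been measured. It differs from compound 3 in one place: trifluoromethyl in place of cyano on an aromatic carbon. Among the compounds with values here, no pair of measured compounds differs by just this change, so the data offer no earlier step to lean on, and the other two compounds carry different groups at that position together with other differences, so they say nothing direct about it. The expected step of a 1.6-fold higher number from compound 3 to compound 4 (0.20 log units; within the scatter) is therefore small, within the scatter or a little above it. The estimate for compound 4 in this assay is 350 nM, with a range from 120 nM to 1200 nM.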

Compound 4, half-maximal inhibitory concentration: 760 nM
Beside the measured number, compound 4's estimate is 2.2-fold (0.34 log units) below it, and the stated range covers the measured number.
By their numbers in this assay, from the lowest: compound 3; then compound 4; then compound 2; then compound 1.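

In this assay, going by these compounds alone, the exchange of cyano for trifluoromethyl on this aromatic carbon gives a 3.5-fold higher number from compound 3 to compound 4 (0.54 log units; beyond the scatter), the first reading of this position with the rest of the molecule held constant. The earlier compounds shown here differ from one another in more than one place, whereas this pair shows that the group at this carbon alone can move the number beyond the scatter, with the 3-cyanophenyl compound lower than the 3-(trifluoromethyl)phenyl compound, though only modestly. Nothing available bears on what lies behind this step.

This single pair leaves open whether the same exchange would give a similar step with the other ester groups of the series. It also leaves open how an amine, a carboxylic acid or a methoxy group on this aromatic carbon would read.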